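The source may report more compounds than this note shows. Statements on the series, on what has been measured and on what is new or still open speak of the compounds shown alone.

Measured so far:
- compound 1 `C=C(Br)C(=O)Nc1ccc(C(=O)/C=C/c2cccc(OC)c2OC)cc1`: 550 nM
- compound 2 `C=C(Br)C(=O)Nc1ccc(C(=O)/C=C/c2ccc(OC)c(OC)c2OC)cc1`: 530 nM

Both values come from a functional assay on FM3A cells (Mus musculus) for antiproliferative activity, with a stated time of 48 h; a lower number here means a stronger inhibitor, a higher number a weaker inhibitor. In this assay compound 2 gives 530 nM, and compound 1 gives 550 nM. These two numbers lie within the scatter of each other, so the pair cannot be ranked.

The unmeasured compound 3 `COc1ccc(/C=C/C(=O)c2ccc(N)cc2)c(OC)c1OC` alters compound 2 at a single place: hydrogen in place of (1-bromoethenyl)carbonyl on a nitrogen on an aromatic ring. Hydrogen stands in place of (1-bromoethenyl)carbonyl on a nitrogen on an aromatic ring, which leaves a plain amino group.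

Within the data shown here, the only measured step, a 1.0-fold lower number from compound 1 to compound 2 (0.02 log units; within the scatter), is methoxy in place of hydrogen on an aromatic carbon. It lies within the scatter and does not touch this nitrogen. Both measured compounds carry the (1-bromoethenyl)carbonyl, so the data contain no direct measure of losing it.

Removing a whole group is a far larger edit than that methoxy change, so a clear loss of activity is a judgement rather than a measured trend. The expected step is a 15-fold higher number from compound 2 to compound 3 (1.18 log units; beyond the scatter), towards a higher number. For compound 3 the estimated value is 8000 nM, with an expected range of 1500 nM to 40000 nM.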

Compound 3, half-maximal inhibitory concentration: 29000 nM
Compound 3: middle estimate off by 3.6-fold (0.56 log units), on the low side; measured number inside the range.
By their numbers in this assay, from the lowest: compounds 2 and 1 (each within the scatter of the next); then compound 3.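

Among these compounds, this is the first look at the nitrogen itself: both earlier compounds carried the (1-bromoethenyl)carbonyl there, and the only earlier edit was a methoxy change elsewhere that stayed within the scatter. In this assay, replacing that group with hydrogen to leave a plain amino group gives a 55-fold higher number from compound 2 to compound 3 (1.74 log units; beyond the scatter), so in this pair much of the antiproliferative strength goes with the ((1-bromoethenyl)carbonyl)amino group and not with the rest of the structure alone, although compound 3 still gives a finite value of 29000 nM. No supporting measurement is available to say what lies behind a loss of this size.

The step removes the whole group at once, so it leaves open which part counts: an acetyl group on the same nitrogen, a propenoyl group lacking the bromine, or a chlorine in place of the bromine would each tell the parts apart. As far as these compounds go, whether the same removal costs as much on the core of compound 1, with its two methoxy groups, also remains open.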